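The source may report more compounds than this note shows. Statements on the series, on what has been measured and on what is new or still open speak of the compounds shown alone.

Notes on the series. Compound 1 `CCCc1nc2ccccc2c(=O)n1/N=C/c1ccc(Oc2ccc(Cl)cc2)cc1` gives 5.78 in a physicochemical assay for lipophilicity, in phosphate buffer, measured as octanol-water partition; on this read-out higher numbers stand for higher lipophilicity and lower numbers for lower lipophilicity. Compound 2 `O=c1c2ccccc2nc(-c2ccccc2)n1/N=C/c1ccc(Oc2ccc(Br)cc2)cc1` differs from compound 1 in two places. In this assay compound 2 gives 6.39. Compound 3 `CCCc1nc2ccccc2c(=O)n1/N=C/c1ccc(Oc2ccc(Cl)c(C)c2)cc1` gives 6.02 in this assay and stands second highest of the three numbers; its nearest neighbour is compound 1, its furthest compound 2, whose value lies beyond the scatter from it. For the measured compounds named here, the only single-point step available, a number 0.24 log units higher from compound 1 to compound 3 (within the scatter), concerns the methyl group alone.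

Compound 4 `CCCc1nc2ccccc2c(=O)n1/N=C/c1ccc(Oc2ccc3ccccc3c2)cc1` carries the change (naphthalen-2-yl in place of 4-chloro-3-methylphenyl on an oxygen on an aromatic ring). Going by the values given here, no measured step covers the removal of the chlorine or the gain of a second fused aromatic ring, so the methyl step from compound 1 to compound 3 bears on it only in part. With the chlorine and methyl leaving and two rings entering, the expected net movement in this assay is a number 0.02 log units lower from compound 3 to compound 4 (within the scatter), none beyond the scatter. For compound 4 the estimated value in this assay is 6, with a range from 5.6 to 6.4.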

Compound 4, partition coefficient: 6.12
Compound 4: the middle estimate sits 0.12 log units below what was measured; the range from low to high includes it.
By their numbers in this assay, from the lowest: compounds 1, 3, 4 and 2 (each within the scatter of the next, the first and the last beyond it).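

In this assay, on an oxygen on an aromatic ring, naphthalen-2-yl in place of 4-chloro-3-methylphenyl gives a step that does not separate the two groups (a number 0.10 log units higher from compound 3 to compound 4 (within the scatter)). Naphthalen-2-yl in place of 4-chlorophenyl at the same position gives the first step here that clears the scatter, though only modestly (a number 0.34 log units higher from compound 1 to compound 4 (beyond the scatter)). Nothing in hand accounts for either step.

Compound 2 differs from compound 1 in two places, leaving neither change with a step of its own. Also open, going by these compounds, is how a carbon-only aromatic group at this position compares with an amine or a carboxylic acid in this assay.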